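The compounds below may be only part of what the source reports. "The series", "measured", "known", "first", "only" and "open" are said of these compounds alone.

Measured compounds:
Compound 1 `NS(=O)(=O)CC(=O)NCCSc1nonc1/C(=N/O)Nc1cccc(Cl)c1`: in an ADME assay on microsomes from liver (Homo sapiens) for metabolic stability (on this read-out higher numbers stand for a longer-lived compound and lower numbers for a shorter-lived compound), compound 1 gives > 3 h, which is a limit of the assay and not a number.
Compound 2 `NS(=O)(=O)CC(=O)NCCSc1nonc1/C(=N/O)Nc1cccc(Br)c1`: in this assay compound 2 gives > 3 h, also a limit of the assay.
Compound 3 `CS(=O)(=O)CC(=O)NCCSc1nonc1/C(=N/O)Nc1ccc(F)c(C(F)F)c1`: in this assay compound 3 gives 1.27 h.

For the measured compounds named here, compound 3 thus carries the only real number; the other two values sit at the limit of > 3 h in this assay, at which 2 of the 3 values shown sit. Going by the values given here, the one step between measured compounds, a step that the two limits leave unreadable from compound 1 to compound 2, cannot be sized.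

Compound 4 `O=C(NCCSc1nonc1/C(=N/O)Nc1ccc(F)c(C(F)F)c1)C1CS(=O)(=O)C1` differs from compound 3 by a group of 6 heavy atoms (3 carbon, 2 oxygen, 1 sulfur; one four-membered non-aromatic ring with 1 hetero atom) in place of a group of 5 heavy atoms (2 carbon, 2 oxygen, 1 sulfur; no ring), on a carbonyl carbon. Among the compounds with values here, no measured step touches this part of the molecule, so nothing among the measured compounds indicates a change beyond the scatter. Compound 4 is therefore expected to stay close to compound 3, with a step of a 1.0-fold higher number from compound 3 to compound 4 (0.01 log units; within the scatter). The estimate for compound 4 in this assay is 1.3 h, with a range from 0.6 h to 2.7 h.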

Compound 4, half-life: 1.28 h
Compound 4: the middle estimate sits 1.0-fold (0.01 log units) above what was measured, within the range that was stated.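

In this assay, the group with one four-membered non-aromatic ring in place of (methylsulfonyl)methyl, on a carbonyl carbon, gives a 1.0-fold higher number from compound 3 to compound 4 (0.00 log units; within the scatter). For the compounds shown here, this is the first readable step and the first at this position: a ring can stand on this carbonyl carbon with nothing beyond the scatter on this read-out. It rests on this single pair, which shares one aromatic part.

On these data alone, whether an amine or a carboxylic acid on this carbonyl carbon would read the same stays open. So does whether the ring would read the same with a chloro or bromo aromatic part.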